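The source may hold more compounds than are shown below. What is called first, only, known or untested is meant among the compounds shown, and "the series" means these compounds.

Three compounds built on related cores were tested in a functional assay on MDA-MB-435S cells (Homo sapiens) for cytotoxicity, read by MTT assay, with a stated time of 72 h; on this read-out lower numbers stand for stronger inhibition and higher numbers for weaker inhibition. Compound 1 `Cc1cc(C)nc(SCc2cc(=O)c3cc(Cl)ccc3o2)n1` and compound 2 `Cc1ccc2oc(CSc3nc(C)cc(C)n3)cc(=O)c2c1` share one core and differ in a single group, while compound 3 `Cc1ccc2oc(CSc3nnc(C)s3)cc(=O)c2c1` carries a different core; the difference between the two cores is not broken down here. In this assay compound 1 gives > 25000 nM, which is a limit of the assay and not a number. Compound 2 gives > 25000 nM, again a limit rather than a number. Compound 3 gives > 25000 nM, also a limit. The change from compound 2 to compound 1 is chloro in place of methyl on an aromatic carbon. The size of the step that the two limits leave unreadable from compound 2 to compound 1 cannot be read because the limit of > 25000 nM in this assay, at which 3 of the 3 values shown sit, hides both ends of it.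

Compound 4 `Cc1nnc(SCc2cc(=O)c3cc(Cl)ccc3o2)s1` has not yet been measured. Within the data shown here, it is made from compound 3 by chloro in place of methyl on an aromatic carbon, the same change, at the same place, as the one made from compound 2 to compound 1. With that earlier step unreadable and all three measured compounds sitting at the limit, the expectation for compound 4 rests on compound 3, which gives > 25000 nM in this assay, and on the unreadable step that the two limits leave unreadable from compound 2 to compound 1. Compound 4 is therefore expected to give about 30000 nM in this assay, most likely reported once more only as a limit, with an estimated range from 8000 nM to 120000 nM should a number appear. The step expected here is a step that the limit leaves unreadable from compound 3 to compound 4.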

Compound 4, half-maximal inhibitory concentration: > 25000 nM
Compound 4: a limit, no number; the forecaster's own chance of this, stated with the estimate: 85%; the middle value lies beyond the limit too.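

No size can be read for the step from compound 3 to compound 4, or for the matching step from compound 2 to compound 1, because both ends of each step are hidden by the same limit: the limit of > 25000 nM in this assay, at which 4 of the 4 values shown sit.

The compounds shown leave open whether chloro in place of methyl, or the difference between the two cores, changes the result at all in this assay.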